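This account rests on a few compounds, and the source may have more. Where it says the series, first, only, none or still open, it means among the compounds named here.

Compound 1 `Cc1ccc(-c2ccccc2NCC2=NCCN2)n1C`: 78%
Compound 2 `Cn1cccc1-c1ccccc1NCC1=NCCN1`: 103%
Compound 3 `CCCn1ncnc1-c1ccccc1NCC1=NCCN1`: 96%

These three compounds were measured in a functional assay with Alpha-1A adrenergic receptor (Homo sapiens) as the target, read by calcium flux; on this read-out lower numbers stand for smaller maximal responses and higher numbers for larger maximal responses. Compound 2 stands at the top of the numbers shown, with 103%. The nearest is compound 3, which gives 96%, a number within the scatter of compound 2, so the two cannot be told apart. The furthest is compound 1, which gives 78%, and the step of a number 25 percentage points higher from compound 1 to compound 2 (beyond the scatter) lies beyond the scatter.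

Compound 4 `Cn1ccnc1-c1ccccc1NCC1=NCCN1` has not yet been measured. It differs from compound 2 in one place: 1-methyl-1H-imidazol-2-yl in place of 1-methyl-1H-pyrrol-2-yl on an aromatic carbon. Among the compounds with values here, no measured step concerns this kind of exchange. Within the data shown here, the one step measured, a number 25 percentage points higher from compound 1 to compound 2 (beyond the scatter), concerns a different change and does not bear on it. Among the measured compounds shown here, the only guide is that compound 2 and compound 3, which differ in the group on that carbon, give numbers within the scatter of each other. Compound 4 is therefore expected to stay close to compound 2, with an estimated step of a number 5 percentage points lower from compound 2 to compound 4 (within the scatter), not beyond the scatter. The estimate for compound 4 in this assay is 98%, with a range from 85% to 110%.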

Compound 4, largest response reached (reported as maximal response), in percent of the reference or control that the assay uses: 88%
The estimate for compound 4 lay 10 percentage points above the measured number, and the stated range covers the measured number.
By their numbers in this assay, from the lowest: compounds 1, 4, 3 and 2 (each within the scatter of the next, the first and the last beyond it).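

The step of a number 15 percentage points lower from compound 2 to compound 4 (beyond the scatter) is the first listed step in this assay that concerns the group on this aromatic carbon itself, and it shows that the read-out is sensitive to the identity of that five-membered aromatic ring. Both groups have the same number of heavy atoms, and 1-methyl-1H-imidazol-2-yl has one more nitrogen and one fewer carbon than 1-methyl-1H-pyrrol-2-yl, so this small exchange of ring atoms is enough to move the number beyond the scatter. Nothing shown here explains why the number falls with this exchange.

As far as these compounds go, it remains open whether the step depends on the methyl on the ring nitrogen, which a 1H-imidazol-2-yl group would test, or whether a methyl on a ring carbon of the 1-methyl-1H-imidazol-2-yl group would lower the number further, as the methyl on the ring carbon of compound 1 goes with a lower number than compound 2 gives. From the compounds shown here alone, how a six-membered group such as phenyl at this position would compare with compound 2 in this assay also stays unknown.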